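The compounds below may be only part of what the source reports. "The series", "measured", "known", "first", "only" and "open" are said of these compounds alone.

Measured: compound 1 `CCCCNc1nc(N)nc2c1CN(C(C)=O)CC2` gives 0.5 uM in an assay on HEK293 cells for agonist activity at Toll-like receptor 8 (Homo sapiens), read by a luciferase reporter, with a stated time of 6 h; a lower number here means that less compound is needed, a higher number that more compound is needed for the effect; compound 2 `CCCCNc1nc(N)nc2c1CN(Cc1ccncc1)CC2` gives 0.29 uM.

Compound 2 holds the lower of the two numbers in this assay, though its gap to compound 1, a 1.7-fold lower number from compound 1 to compound 2 (0.24 log units; within the scatter), is within the scatter. Compound 3 `CCCCNc1nc(N)nc2c1CN(C(=O)C1CCC1)CC2` is not yet measured. The change is cyclobutylcarbonyl in place of (pyridin-4-yl)methyl on an amine nitrogen in a ring. Among the measured compounds shown here, the one measured step that bears on it, a 1.7-fold lower number from compound 1 to compound 2 (0.24 log units; within the scatter), exchanged an acyl group for the (pyridin-4-yl)methyl group without moving beyond the scatter; compound 3 returns to an acyl group on the same nitrogen. No step beyond the scatter is therefore expected, a 1.7-fold higher number from compound 2 to compound 3 (0.24 log units; within the scatter). Compound 3 is estimated at 0.5 uM, range 0.2 uM to 1.3 uM.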

Compound 3, minimum effective concentration: 0.4 uM
Compound 3: middle estimate off by 1.3-fold (0.10 log units), on the high side, and the stated range covers the measured number.
By their numbers in this assay, from the lowest: compounds 2, 3 and 1 (each within the scatter of the next).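

In this assay, cyclobutyl in place of methyl on a carbonyl carbon gives a 1.3-fold lower number from compound 1 to compound 3 (0.10 log units; within the scatter) and so does not separate these two acyl groups on the amine nitrogen in a ring. Cyclobutylcarbonyl in place of (pyridin-4-yl)methyl gives a 1.4-fold higher number from compound 2 to compound 3 (0.14 log units; within the scatter), so a four-membered ring of carbon only and a six-membered aromatic ring are not told apart here either. No measurement on hand accounts for these numbers.

Among the compounds shown here, no step at this nitrogen yet lies beyond the scatter. Going by these compounds, whether a carboxylic acid, a primary amine or a longer alkyl chain there would give such a step remains open.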